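Pyridin-2-yl for pyrimidin-2-yl on the ring amine nitrogen

This account rests on a few compounds, and the source may have more. Where it says the series, first, only, none or still open, it means among the compounds named here.

Measured so far in a functional assay on L5178Y cells (Mus musculus) for antiproliferative activity, read by MTT assay; on this read-out higher numbers stand for weaker inhibition and lower numbers for stronger inhibition:
compound 1 `CC(C)(C)c1ccc(OCCCCN2CCN(c3ncccn3)CC2)cc1`: 11.3 nM
compound 2 `CC(=O)c1ccc(OCCCN2CCN(c3ncccn3)CC2)cc1`: 53.2 nM
compound 3 `CCC(C)(C)c1ccc(OCCCCN2CCN(c3ncccn3)CC2)cc1`: 17.7 nM

Compound 1 has the lowest number of the three. Compound 3 sits nearest to it, and the step of a 1.6-fold higher number from compound 1 to compound 3 (0.19 log units; within the scatter) stays within the scatter, so these two cannot be ordered. Among the measured compounds shown here, compound 2 lies furthest from compound 1 and its number stands beyond the scatter, but compound 2 differs from compound 1 in more than one place, so no single step is computed for that pair.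

Compound 4 `CC(C)(C)c1ccc(OCCCCN2CCN(c3ccccn3)CC2)cc1` is the next compound, not yet measured. It differs from compound 1 as follows: pyridin-2-yl in place of pyrimidin-2-yl on an amine nitrogen in a ring. For the measured compounds named here, none of the measured steps touches this part of the molecule; the only single-point step among the measured compounds, a 1.6-fold higher number from compound 1 to compound 3 (0.19 log units; within the scatter), concerns a methyl on the saturated chain and says nothing about the aromatic group on the amine nitrogen in the ring. The expectation therefore rests on compound 1 alone, and the estimated step is a 1.1-fold higher number from compound 1 to compound 4 (0.03 log units; within the scatter), that is, nothing beyond the scatter in either direction. Compound 4 is expected at 12 nM, in the range 5 nM to 30 nM.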

Compound 4, half-maximal inhibitory concentration: 11.9 nM
Compound 4: middle estimate off by 1.0-fold (0.00 log units), on the high side; low and high end bracket the measured number.
By their numbers in this assay, from the lowest: compounds 1, 4 and 3 (each within the scatter of the next); then compound 2.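

In this assay, among the compounds shown here, pyridin-2-yl in place of pyrimidin-2-yl on the amine nitrogen in the ring gives a 1.1-fold higher number from compound 1 to compound 4 (0.02 log units; within the scatter), the first reading at this position, and it leaves the two compounds unordered. The group that leaves carries 2 hydrogen-bond acceptors and the group that enters carries 1, so on the core of compound 1 this read-out tolerates the loss of one ring nitrogen from the aromatic group without a step beyond the scatter. No measurement here bears on why the two groups read alike.

Still open, from the compounds shown here alone, is how much of the aromatic group this position requires: a phenyl ring, which has no ring nitrogen, or a simple methyl on the same amine nitrogen would test this further. Going by these compounds, the reading also comes from one pair only, so it remains open whether the same exchange would give a step of similar size on the core of compound 2, which stands beyond the scatter from compound 1.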